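This account rests on a few compounds, and the source may have more. Where it says the series, first, only, none or still open, it means among the compounds named here.

Values in a functional assay on A549 cells (Homo sapiens) for antiproliferative activity, read by MTT assay, with a stated time of 24 h; a higher number here means a weaker inhibitor, a lower number a stronger inhibitor:
Compound 1 `C=CC(C)(C)c1cc(-c2ccc(OC)cc2)ccc1O`: > 100000 nM (a limit, not a number)
Compound 2 `C=CCc1cc(C=O)c(OCC)c(-c2ccc(OCC)c(CC=C)c2)c1`: 39000 nM
Compound 3 `C=CCc1cc(-c2ccc(C(F)(F)F)cc2)ccc1OC`: > 100000 nM (a limit, not a number)
Compound 4 `C=CCc1ccc(OCC)c(-c2ccc(OCC)c(CC=C)c2)c1`: not yet measured

Among the compounds with values here, compound 2 gives the only actual number, 39000 nM. The other two entries are limits. Compound 4 differs from compound 2 at one place: hydrogen in place of formyl on an aromatic carbon. The hydrogen replaces the formyl on an aromatic carbon, ortho to an ethoxy group. Within the data shown here, no measured step sizes this change. A modest weakening in this assay is expected, and a result reported only as a limit is possible. The expected change is a 1.5-fold higher number from compound 2 to compound 4 (0.19 log units; within the scatter). For compound 4 the estimate is 60000 nM, with an expected range of 25000 nM to 100000 nM.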

Compound 4, half-maximal inhibitory concentration: > 124000 nM
Compound 4 ended at the assay's limit (the forecaster's own chance of this, stated with the estimate: 35%); middle value at least 2.0-fold (0.31 log units) from the limit.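

In this assay, within the data shown here, hydrogen in place of formyl on the aromatic carbon ortho to an ethoxy group gives an at least 3.1-fold higher number from compound 2 to compound 4 (0.50 log units; beyond the scatter), the first step with any size attached. With the formyl group, compound 2 gives a real number, 39000 nM. Compound 4 gives > 124000 nM, a limit and not a number, so the step is only a minimum: the limit of > 124000 nM in this assay, at which 1 of the 4 values shown sits.

On these data alone, the true size of the step stays open. So does whether a nitrile, a carboxylic acid or a hydroxymethyl group on this carbon would serve as formyl does.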